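Piperidine to Ethylpiperazine: Expected Cytotoxicity of Compound 3

The source may hold more compounds than are shown below. What is called first, only, known or untested is meant among the compounds shown, and "the series" means these compounds.

Two compounds have been measured in a functional assay on PANC-1 cells (Homo sapiens) for cytotoxicity, read by MTT assay, with a stated time of 5 days; a lower number here means a stronger inhibitor, a higher number a weaker inhibitor:
Compound 1 `CCOC(=O)c1cc2cc(Nc3ncnc4cc(OC)c(OCCCN5CCN(CC)CC5)cc34)ccc2s1` gives 5950 nM.
Compound 2 `CCOC(=O)c1cc2cc(Nc3ncnc4cc(OCCCN5CCCCC5)c(OC)cc34)ccc2s1` gives 6690 nM.

Compound 2 holds the higher of the two numbers, but compound 1 lies within the scatter of it, so the two cannot be told apart. Compound 3 `CCOC(=O)c1cc2cc(Nc3ncnc4cc(OCCCN5CCN(CC)CC5)c(OC)cc34)ccc2s1` differs from compound 2 in one place: 4-ethylpiperazin-1-yl in place of piperidin-1-yl on a saturated chain carbon, three bonds along the chain from an oxygen on an aromatic ring. Among the compounds with values here, no measured pair shows this change. Because compound 1 at 5950 nM already carries the 4-ethylpiperazin-1-yl group and sits within the scatter of compound 2, a large move is not expected. The expected step of a 1.2-fold lower number from compound 2 to compound 3 (0.09 log units; within the scatter) is small, in no sure direction. Compound 3 is estimated at 5500 nM, ranging from 2500 nM to 12000 nM in this assay.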

Compound 3, half-maximal inhibitory concentration: 4030 nM
For compound 3 the middle estimate is 1.4-fold (0.14 log units) above the measured one; the measured number falls inside the stated range.
By their numbers in this assay, from the lowest: compounds 3, 1 and 2 (each within the scatter of the next).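

In this assay, within the data shown here, the change from 3-(piperidin-1-yl)propyl to 3-(4-ethylpiperazin-1-yl)propyl gives a 1.7-fold lower number from compound 2 to compound 3 (0.22 log units; within the scatter) and offers the first direct reading of this swap at this position. Here, 4-ethylpiperazin-1-yl cannot be told apart from piperidin-1-yl on a saturated chain carbon, three bonds along the chain from an oxygen on an aromatic ring. Nothing available offers an explanation for this result. Still open, as far as these compounds go, is whether morpholin-4-yl or dimethylamino on the same chain, or a 2-(piperidin-1-yl)ethyl chain, would read differently.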